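This account rests on a few compounds, and the source may have more. Where it says the series, first, only, none or still open, it means among the compounds named here.

Compound 1 `O=C(NCC1CCCCC1)c1cccc(/C=C2\CC(=O)N(c3ccccc3)C2=O)c1` is a benzamide-type compound whose amide nitrogen carries a cyclohexylmethyl group. In an ADME assay on SW480 cells (Homo sapiens) for cytotoxicity, read by MTT assay, with a stated time of 72 h (a lower number here means a stronger inhibitor, a higher number a weaker inhibitor), compound 1 gives > 100000 nM, which is a limit of the assay rather than a measured number. Compound 2 `CCCCCN1C(=O)C/C(=C\c2cccc(C(=O)NCCCC)c2)C1=O` also returns only a limit in this assay, namely > 100000 nM. Compound 3 `COc1ccc(NC(=O)c2cccc(CC3CC(=O)N(c4ccc(C)cc4)C3=O)c2)cc1` likewise stops at a limit, > 100000 nM. So compound 1 stands where every measured compound here stands, at the limit of > 100000 nM in this assay, at which 3 of the 3 values shown sit, and nothing on the numbers separates the three.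

Compound 4 `CCc1ccc(NC(=O)c2cccc(/C=C3\CC(=O)N(c4ccccc4)C3=O)c2)cc1` differs from compound 1 in one place: 4-ethylphenyl in place of cyclohexylmethyl on an amide-type nitrogen. Among the compounds with values here, no measured pair isolates this change, so its size cannot be read from the data. Compound 3 does show that an aromatic group on the amide nitrogen, in its case 4-methoxyphenyl, leaves a compound at > 100000 nM. The expected step in this assay from compound 1 to compound 4 is therefore a step that the limit leaves unreadable from compound 1 to compound 4, none beyond the scatter. Compound 4 is expected to give about 150000 nM in this assay, somewhere between 50000 nM and 500000 nM, most probably again as a limit only.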

Compound 4, half-maximal inhibitory concentration: > 100000 nM
Compound 4 was reported as a limit; the forecaster's own chance of this, stated with the estimate: 85%; the middle value does not contradict the limit.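

Compound 4 gives > 100000 nM in this assay, which is a limit and not a number. Within the data shown here, compound 1 also stops at a limit, so no step between compound 1 and compound 4 can be read. The compounds shown leave open which change to the shared core, if any, would give a measurable value, since all of them stop at the same limit: the limit of > 100000 nM in this assay, at which 4 of the 4 values shown sit.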